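The source may hold more compounds than are shown below. What is called first, only, known or untested is meant among the compounds shown, and "the series" means these compounds.

Measured so far:
compound 1, `CC[C@@H](CCn1cncn1)c1ccccc1`: 89.9 ug/mL
compound 2, `CC[C@@H](CCn1cncn1)c1ccc(F)cc1`: 90.3 ug/mL
compound 3, `CC[C@H](CCn1cncn1)c1ccc(Cl)cc1`: 50.6 ug/mL

All three numbers come from an ADME assay on HEp-2 cells (Homo sapiens) for cytotoxicity, read by MTT assay, with a stated time of 3 days; a higher number here means that more compound is tolerated, a lower number that less compound is tolerated. The three compounds share one core and differ only at the aromatic ring and at the drawn configuration of the chain carbon. Within the data shown here, the single step in which two measured compounds differ in one place is a 1.0-fold higher number from compound 1 to compound 2 (0.00 log units; within the scatter), so swapping a hydrogen for a fluoro on the aromatic ring left the tolerated concentration unchanged for practical purposes. Compound 3, which carries a chloro instead, gives a number that sits within the usual scatter of both compound 1 and compound 2, so no ranking among the three can be drawn from these data.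

Compound 4, `CC[C@@H](CCn1cncn1)c1ccc(Cl)cc1`, is the mirror-image partner of compound 3: the two compounds have the same atoms and bonds and differ only in configuration as drawn: 1 of 1 stereo elements differ; a stereocentre at a saturated chain carbon is drawn R in compound 3 and S in compound 4. Among the measured compounds shown here, no measured pair among compounds 1, 2 and 3 differs in configuration, so there is no step that speaks directly to this change; the only measured step, that from hydrogen to fluoro, concerns a different kind of alteration and was itself within the scatter. In the absence of any shown effect, the change from compound 3 to compound 4 is expected to produce a 1.1-fold higher number from compound 3 to compound 4 (0.04 log units; within the scatter), that is, nothing beyond the scatter. Compound 4 is therefore estimated at 55 ug/mL, with a likely range from 30 ug/mL to 100 ug/mL.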

Compound 4, half-maximal cytotoxic concentration: 55.1 ug/mL
For compound 4 the middle estimate is 1.0-fold (0.00 log units) below the measured one; the measured number falls inside the stated range.
By their numbers in this assay, from the lowest: compounds 3, 4, 1 and 2 (each within the scatter of the next).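

In this assay, this pair gives the first direct test of the drawn configuration at the saturated chain carbon, and the result is a 1.1-fold higher number from compound 3 to compound 4 (0.04 log units; within the scatter), so with chloro on the aromatic ring, the two configurations cannot be told apart in this measurement. The comparison is a clean one, with no other structural change to take into account: the fact that compounds 3 and 4 differ only in the configuration as drawn. Compound 4 also allows chloro to be compared with other aromatic substituents under the same drawn configuration, and the steps are a 1.6-fold lower number from compound 2 to compound 4 (0.21 log units; within the scatter) and a 1.6-fold lower number from compound 1 to compound 4 (0.21 log units; within the scatter), so neither replacement shows an effect that stands clear of the scatter.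

The compounds shown leave open whether configuration at this carbon would matter with a different group on the aromatic ring, such as a methoxy group or a carboxylic acid. They also do not tell whether an amine or a longer chain elsewhere on the shared core would move the tolerated concentration beyond the scatter.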